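Trifluoromethyl in place of bromo in the series

The compounds below may be only part of what the source reports. "The series", "measured", "known", "first", "only" and "open" are said of these compounds alone.

In a functional assay on HUVEC cells (Homo sapiens) for inhibition, with a stated time of 4 days (on this read-out lower numbers stand for stronger inhibition and higher numbers for weaker inhibition), compound 1 (`COc1ccc(C(N)=O)cc1/C=C/c1ccc(Cl)cc1`) gives 87 nM and compound 2 (`COc1ccc(C(N)=O)cc1/C=C/c1ccccc1`) gives 2400 nM while compound 3 (`COc1ccc(C(N)=O)cc1/C=C/c1ccc(Br)cc1`) gives 560 nM as the middle of the three numbers. Compound 4 (`COc1ccc(C(N)=O)cc1/C=C/c1ccc(C(F)(F)F)cc1`) carries trifluoromethyl in place of bromo on an aromatic carbon, para to a large group (trifluoromethyl in place of bromo on an aromatic carbon). The nearest evidence is bromo in place of chloro (a 6.4-fold higher number from compound 1 to compound 3 (0.81 log units; beyond the scatter)) and bromo in place of hydrogen (a 4.3-fold lower number from compound 2 to compound 3 (0.63 log units; beyond the scatter)), both modest, and hydrogen in place of chloro (a 28-fold higher number from compound 1 to compound 2 (1.44 log units; beyond the scatter)), which is large. Within the data shown here, no trifluoromethyl compound has a measured value, so the direction stays open. The expected step is none beyond the scatter (a 1.1-fold higher number from compound 3 to compound 4 (0.03 log units; within the scatter)) in this assay but a modest one either way remains possible. For compound 4 the estimated value is 600 nM with 120 nM to 2500 nM as the expected range.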

Compound 4, half-maximal inhibitory concentration: 880 nM
Beside the measured number, compound 4's estimate is 1.5-fold (0.17 log units) below it; measured number inside the range.
By their numbers in this assay, from the lowest: compound 1; then compounds 3 and 4 (each within the scatter of the next); then compound 2.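

Trifluoromethyl in place of bromo at this position, on an aromatic carbon para to a large group, does not separate the two compounds (a 1.6-fold higher number from compound 3 to compound 4 (0.20 log units; within the scatter)). Trifluoromethyl still improves on hydrogen (a 2.7-fold lower number from compound 2 to compound 4 (0.44 log units; beyond the scatter)) but falls well short of chloro (a 10-fold higher number from compound 1 to compound 4 (1.00 log units; beyond the scatter)), so in these four compounds every substituent beats hydrogen and chloro alone stands apart. No measurement here accounts for the standing of chloro.

Open, as far as these compounds go, is whether fluoro or methyl at this position would approach chloro. A methoxy or an amine there would show whether the trend holds beyond halogens and trifluoromethyl.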